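Swapping a triazolylmethyl arm for a chlorostyryl arm

The source may report more compounds than this note shows. Statements on the series, on what has been measured and on what is new or still open speak of the compounds shown alone.

Compound 1 `NS(=O)(=O)c1cc(-c2nnc(CN3CCC(Cc4ccccc4)CC3)o2)c(Cl)cc1SCc1ccccc1`: 16000 nM
Compound 2 `NS(=O)(=O)c1cc(-c2nnc(CN3CCN(c4ccc(Cl)cc4)CC3)o2)c(Cl)cc1SCc1ccccc1`: 11000 nM
Compound 3 `CC(C)(O)c1cn(Cc2nnc(-c3cc(S(N)(=O)=O)c(SCc4ccccc4)cc3Cl)o2)nn1`: 68000 nM

Of the compounds shown here, three sharing a common core have been tested in a functional assay on HeLa cells (Homo sapiens) for cytotoxicity, read by MTT assay, with a stated time of 72 h; on this read-out higher numbers stand for weaker inhibition and lower numbers for stronger inhibition. Compound 3 stands at the top of the three numbers: in this assay compound 3 gives 68000 nM, and both its gaps, to compound 1 and to compound 2, lie beyond the usual scatter, so compound 3 is the least potent of the measured set. Compound 1 and compound 2 sit within scatter of each other.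

The next compound, compound 4 `NS(=O)(=O)c1cc(-c2nnc(/C=C/c3cccc(Cl)c3)o2)c(Cl)cc1SCc1ccccc1`, changes the arm hanging from the core of compound 3: 2-(3-chlorophenyl)ethenyl in place of (4-(1-hydroxy-1-methylethyl)-1H-1,2,3-triazol-1-yl)methyl on an aromatic carbon. Among the measured compounds shown here, no measured pair shows this exact step, so its size can only be inferred from the neighbours. Since compound 1 gives 16000 nM and compound 2 gives 11000 nM with other arms at the same place, compound 4 is expected to move towards that range, a step of a 5.7-fold lower number from compound 3 to compound 4 (0.75 log units; beyond the scatter) towards stronger inhibition. Compound 4 is therefore estimated at 12000 nM, within 4000 nM to 40000 nM.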

Compound 4, half-maximal inhibitory concentration: 16000 nM
For compound 4 the middle estimate is 1.3-fold (0.12 log units) below the measured one; the range from low to high includes it.
By their numbers in this assay, from the lowest: compounds 2, 1 and 4 (each within the scatter of the next); then compound 3.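

In this assay, among the compounds shown here, the step of a 4.3-fold lower number from compound 3 to compound 4 (0.63 log units; beyond the scatter) is the first change in a single place that can be read in this set, and it shows that the arm on this aromatic carbon can shift the number beyond the scatter. Compound 4, whose arm holds no hydrogen-bond donor or acceptor, stands within the scatter of compound 1 and compound 2, so three quite different arms give values that cannot be told apart in this assay. Nothing measured here gives a reason for the step.

The compounds shown do not separate the loss of the triazole arm from the entry of the chlorostyryl arm, nor the parts played by the chlorine and the double bond. From the compounds shown here alone, how a plain styryl arm, a saturated two-carbon link or a carboxylic acid on the phenyl ring would read at this position stays open.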